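Swapping the hydroxy of compound 2 for methyl

This account rests on a few compounds, and the source may have more. Where it says the series, first, only, none or still open, it means among the compounds named here.

In a functional assay on U2OS cells (Homo sapiens) for cytotoxicity, read by MTT assay, with a stated time of 48 h (a lower number here means a stronger inhibitor, a higher number a weaker inhibitor), compound 1 (`Fc1cccc(-c2nc(Nc3ccccc3)c3cc(F)ccc3n2)c1`) gives 47600 nM and compound 2 (`Oc1ccccc1Nc1nc(-c2cccc(F)c2)nc2ccc(F)cc12`) gives 41400 nM so the two values stand within the scatter of each other, and compound 2 has no measured advantage. Compound 3 (`Cc1ccccc1Nc1nc(-c2cccc(F)c2)nc2ccc(F)cc12`) keeps the core of compound 2 and carries methyl in place of hydroxy on an aromatic carbon, ortho to a large group (methyl in place of hydroxy on an aromatic carbon). Among the measured compounds shown here, one measured step bears on this change. Adding that same hydroxy in place of hydrogen gave a 1.1-fold lower number from compound 1 to compound 2 (0.06 log units; within the scatter) and so left the number within the scatter in this assay with no sign that this site matters here. Removing the hydroxy in favour of methyl is therefore expected to do little, with an estimated 1.1-fold higher number from compound 2 to compound 3 (0.04 log units; within the scatter) and no shift beyond the scatter in either direction. Compound 3 is estimated at 45000 nM with an expected range from 25000 nM to 80000 nM in this measurement.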

Compound 3, half-maximal inhibitory concentration: > 50000 nM
Compound 3: only a limit was reported (the forecaster's own chance of this, stated with the estimate: 15%); middle value at least 1.1-fold (0.04 log units) from the limit.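

For compound 3, this assay yields only a limit, and the reading of this position stops there: the limit of > 50000 nM in this assay, at which 1 of the 3 values shown sits. Methyl in place of hydroxy gives an at least 1.2-fold higher number from compound 2 to compound 3 (0.08 log units; that floor lies within the scatter), and methyl in place of hydrogen gives an at least 1.0-fold higher number from compound 1 to compound 3 (0.02 log units; that floor lies within the scatter), so both steps are floors and neither shows a change beyond the scatter. Among the compounds shown here, compound 3 adds a third group at this place: across hydrogen, hydroxy and methyl, no step reads as beyond the scatter, yet the two steps into methyl, unlike the step from hydrogen to hydroxy, have no upper bound.

From the compounds shown here alone, how far compound 3 really lies from compound 2 and compound 1 remains open. Also open, going by these compounds, is whether an amine, a methoxy group or a chlorine atom on this aromatic carbon would move the number beyond the scatter in either direction.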